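Moving the methoxy group to another ring position

A few compounds are considered here, and "the series" means these few. Any claim that something is new, unique, unknown or untested is made for them only; others in the source may bear on it.

Compound 1 `COC(=O)c1sc2cc(C#Cc3cccc(N)c3)cnc2c1N` inhibits growth in a functional assay on A375-C5 cells (Homo sapiens) for inhibition, read by sulforhodamine B assay, with a stated time of 48 h (on this read-out higher numbers stand for weaker inhibition of growth and lower numbers for stronger inhibition of growth), giving 11600 nM. Compound 2 `COC(=O)c1sc2cc(C#Cc3ccccc3OC)cnc2c1N` reaches only the limit of this assay, recorded as > 47300 nM, so no exact number exists for it. Among the measured compounds shown here, the single measured step, an at least 4.0-fold higher number from compound 1 to compound 2 (0.61 log units; beyond the scatter), showed weaker inhibition after the change to 2-methoxyphenyl. Compound 3 `COC(=O)c1sc2cc(C#Cc3cccc(OC)c3)cnc2c1N` differs from compound 2 by 3-methoxyphenyl in place of 2-methoxyphenyl on a triple-bonded carbon, matching the substitution pattern of 3-aminophenyl in compound 1. Since compound 2 sits at the limit (the limit of > 47300 nM in this assay, at which 1 of the 2 values shown sits), a move toward stronger inhibition is expected, though a methoxy group is not an amino group. Compound 3 is estimated at 25000 nM, within 8000 nM to 60000 nM, a step of an at least 1.8-fold lower number from compound 2 to compound 3 (0.27 log units; that floor lies within the scatter).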

Compound 3, concentration for 50% growth inhibition: > 75000 nM
Compound 3: a limit, no number; the forecaster's own chance of this, stated with the estimate: 35%; middle value at least 3.0-fold (0.47 log units) from the limit.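

Methoxy in place of amino on an aromatic carbon gives an at least 6.4-fold higher number from compound 1 to compound 3 (0.81 log units; beyond the scatter) in this assay, so weaker inhibition follows this change even with the substitution pattern of compound 1 kept. Compound 3 gives a limit of the assay, not a number: the limit of > 75000 nM in this assay, at which 1 of the 3 values shown sits. The step between compound 2 and compound 3 cannot be read, so 2-methoxyphenyl and 3-methoxyphenyl cannot be ranked against each other.

Going by these compounds, it remains open whether a hydroxyl or a dimethylamino group on that aromatic carbon would keep the inhibition seen with compound 1. On these data alone, the effect of 2-aminophenyl is also open.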